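Replacing a chloropyrimidinylmethyl ether with a thiophenylmethyl group

The source may report more compounds than this note shows. Statements on the series, on what has been measured and on what is new or still open speak of the compounds shown alone.

Three compounds sharing one core have been measured in an assay on CHO cells for displacement of a labelled ligand from melanin-concentrating hormone receptor 1 (Rattus norvegicus), read by scintillation counting, with a stated time of 1 h; on this read-out lower numbers stand for stronger inhibition and higher numbers for weaker inhibition:

Compound 1 `Cn1c(C2CC2)nc2ccc(-n3ccc(OCc4ccc(Cl)cc4)cc3=O)cc21` gives 21 nM.
Compound 2 `Cn1c(C2CC2)nc2ccc(-n3ccc(OCc4cccc(Cl)c4)cc3=O)cc21` gives 72 nM.
Compound 3 `Cn1c(C2CC2)nc2ccc(-n3ccc(OCc4ncc(Cl)cn4)cc3=O)cc21` gives 900 nM.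

Compound 3 stands at the highest number of the three. Compound 2 is nearest and compound 1 furthest, as the steps of a 13-fold higher number from compound 2 to compound 3 (1.10 log units; beyond the scatter) and a 43-fold higher number from compound 1 to compound 3 (1.63 log units; beyond the scatter) show; both lie beyond the scatter.

Compound 4 `Cn1c(C2CC2)nc2ccc(-n3ccc(OCc4cc(C(F)(F)F)cs4)cc3=O)cc21` differs from compound 3 in one place: 4-(trifluoromethyl)thiophen-2-yl in place of 5-chloropyrimidin-2-yl on a saturated chain carbon bound to an oxygen on an aromatic ring. All three measured steps concern the same position, the group on a saturated chain carbon bound to an oxygen on an aromatic ring. Between the two chlorophenyl groups the step of a 3.4-fold higher number from compound 1 to compound 2 (0.54 log units; beyond the scatter) is modest, whereas each exchange toward the 5-chloropyrimidin-2-yl group of compound 3 is large: a 43-fold higher number from compound 1 to compound 3 (1.63 log units; beyond the scatter) and a 13-fold higher number from compound 2 to compound 3 (1.10 log units; beyond the scatter). Every measured exchange at this position has moved the number beyond the scatter, and compound 3 holds the highest one.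

Among the compounds with values here, no measured step matches this exact exchange, so its size is uncertain. Compound 4 is nevertheless expected to give a lower number than compound 3, a step estimated as a 9.0-fold lower number from compound 3 to compound 4 (0.95 log units; beyond the scatter). Compound 4 is estimated at 100 nM, with a range from 25 nM to 400 nM.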

Compound 4, half-maximal inhibitory concentration: 17 nM
Compound 4: the middle estimate sits 5.9-fold (0.77 log units) above what was measured; measured number below the stated range.
By their numbers in this assay, from the lowest: compounds 4 and 1 (each within the scatter of the next); then compound 2; then compound 3.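

The 4-(trifluoromethyl)thiophen-2-yl group shows that this position does not need a six-membered aromatic ring or a chlorine to reach the best numbers seen here, as a 1.2-fold lower number from compound 1 to compound 4 (0.09 log units; within the scatter) leaves compound 4 within the scatter of the 4-chlorophenyl compound. The exchange also separates the new group from both of the other groups: a 53-fold lower number from compound 3 to compound 4 (1.72 log units; beyond the scatter) is large, while a 4.2-fold lower number from compound 2 to compound 4 (0.63 log units; beyond the scatter) is modest but still beyond the scatter. So the three compounds carrying a carbocyclic or sulfur-containing five- or six-membered ring all give clearly lower numbers than the 5-chloropyrimidin-2-yl compound, with compound 3 as the only one set apart by a large step from each of the others. Nothing shown here gives a reason for these steps.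

Ring and substituent change together in this exchange, so the compounds shown leave open how much of the step belongs to each; a plain thiophen-2-yl group or a 5-(trifluoromethyl)pyrimidin-2-yl group would separate the two. Also open, from the compounds shown here alone, is how the number would respond to a longer chain in place of the single saturated chain carbon, or to an amine on the thiophene ring.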